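The source may hold more compounds than are shown below. What is called first, only, known or untested is meant among the compounds shown, and "the series" means these compounds.

Measured in a functional assay with Homo sapiens as the target; a lower number here means a stronger inhibitor, a higher number a weaker inhibitor:
- compound 1 `CC(C)[C@H](NC(=O)COc1cccc2ccccc12)C(=O)N[C@@H](CC(=O)O)C(=O)COc1ccccc1`: 11200 nM
- compound 2 `CC(C)[C@H](NC(=O)COc1cccc2ccccc12)C(=O)N[C@@H](CC(=O)O)C(=O)COc1ccc(F)cc1`: 14300 nM

Compound 2 carries the higher of the two numbers, but its gap to compound 1 lies within the scatter, so the two stand level. Compound 3 `CC(C)[C@H](NC(=O)COc1cccc2ccccc12)C(=O)N[C@@H](CC(=O)O)C(=O)COc1cc(F)ccc1F` is not yet measured. It differs from compound 2 by 2,5-difluorophenyl in place of 4-fluorophenyl on an oxygen on a saturated carbon.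

Going by the values given here, only one measured step bears on this change: a 1.3-fold higher number from compound 1 to compound 2 (0.11 log units; within the scatter), for fluoro in place of hydrogen on an aromatic carbon. That step stays within the scatter, so no shift beyond the scatter is expected in this assay, in either direction. No compound with a 2,5-difluorophenyl has been measured, and the range is kept wide for that reason.

The expected step is a 1.3-fold lower number from compound 2 to compound 3 (0.11 log units; within the scatter). Compound 3 is estimated at 11000 nM, with an expected range of 4500 nM to 24000 nM.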

Compound 3, half-maximal inhibitory concentration: 19700 nM
Compound 3: middle estimate off by 1.8-fold (0.25 log units), on the low side, within the range that was stated.
By their numbers in this assay, from the lowest: compounds 1, 2 and 3 (each within the scatter of the next).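

In this assay, 2,5-difluorophenyl in place of 4-fluorophenyl on the oxygen gives a 1.4-fold higher number from compound 2 to compound 3 (0.14 log units; within the scatter), and 2,5-difluorophenyl in place of phenyl gives a 1.8-fold higher number from compound 1 to compound 3 (0.25 log units; within the scatter). A second fluoro therefore produces no shift beyond the scatter, even when compared with the unsubstituted phenyl, and compound 1, compound 2 and compound 3 stand level. Nothing available accounts for this flat response at the position.

Still open, on these data alone, is whether a group other than fluoro on the phenyl, such as an amine or a carboxylic acid, or a longer saturated chain in place of the phenyl, would move the number beyond the scatter. These three compounds also say nothing about changes elsewhere in the shared core.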